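A few compounds are considered here, and "the series" means these few. Any claim that something is new, unique, unknown or untested is made for them only; others in the source may bear on it.

Three compounds sharing one core have been examined in an ADME assay on cells (Hepatocyte, Rattus norvegicus) for metabolic stability; a lower number here means slower removal, a higher number faster removal of the compound. Compound 1, `O=C(N[C@H]1CN(S(=O)(=O)c2ccccc2)C[C@@H]1C(=O)N1C[C@H]2CCNC[C@H]21)c1cc(-c2ccccc2Cl)on1`, gives 4.7 uL/min. Compound 2, `O=C(N[C@H]1CN(S(=O)(=O)c2ccccc2)C[C@@H]1C(=O)NC[C@@H]1CCCN1)c1cc(-c2ccccc2Cl)on1`, gives 22 uL/min, and compound 3, `CN(C(=O)[C@H]1CN(S(=O)(=O)c2ccccc2)C[C@@H]1NC(=O)c1cc(-c2ccccc2Cl)on1)[C@H]1CCCNC1`, gives 5.8 uL/min. Compound 3 therefore stands second highest of the three numbers: its nearest neighbour is compound 1, with a step of a 1.2-fold higher number from compound 1 to compound 3 (0.09 log units; within the scatter), and its furthest is compound 2, with a step of a 3.8-fold lower number from compound 2 to compound 3 (0.58 log units; beyond the scatter). The unmeasured compound 4 is `O=CN1CCC[C@H](NC(=O)[C@H]2CN(S(=O)(=O)c3ccccc3)C[C@@H]2NC(=O)c2cc(-c3ccccc3Cl)on2)C1`; relative to compound 3 the change is a group of 9 heavy atoms (6 carbon, 2 nitrogen, 1 oxygen; one six-membered non-aromatic ring with 1 hetero atom) in place of a group of 8 heavy atoms (6 carbon, 2 nitrogen; one six-membered non-aromatic ring with 1 hetero atom), on a carbonyl carbon. Both steps recorded so far sit on the same carbonyl carbon, and their sizes were the modest 4.7-fold higher number from compound 1 to compound 2 (0.67 log units; beyond the scatter) and the small 1.2-fold higher number from compound 1 to compound 3 (0.09 log units; within the scatter), so exchanges at this position have not moved this assay far. Because compound 3 gives 5.8 uL/min and the present change keeps the six-membered ring of compound 3 and adds only one oxygen and one double bond outside aromatic rings, the expected step is a 1.4-fold higher number from compound 3 to compound 4 (0.14 log units; within the scatter), lying within the scatter or at most modest. Compound 4 is thus estimated at 8 uL/min, with a range from 3 uL/min to 22 uL/min.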

Compound 4, intrinsic clearance in a liver preparation (reported as CLH), per the amount of preparation that the assay uses: 97 uL/min
Beside the measured number, compound 4's estimate is 12-fold (1.08 log units) below it, outside the stated range (above it).
By their numbers in this assay, from the lowest: compounds 1 and 3 (each within the scatter of the next); then compound 2; then compound 4.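

Exchanges on this carbonyl carbon can move this assay much further than the earlier compounds showed: the step is a 17-fold higher number from compound 3 to compound 4 (1.22 log units; beyond the scatter), even though the entering group keeps the six-membered non-aromatic ring with 1 hetero atom. Keeping that ring is therefore not enough to hold the number low. The same position also carries a 21-fold higher number from compound 1 to compound 4 (1.31 log units; beyond the scatter), and even the smallest of the new steps, a 4.4-fold higher number from compound 2 to compound 4 (0.64 log units; beyond the scatter), lies beyond the scatter, leaving compound 4 with the highest number of the four.

No measurement at hand explains what produces this jump. As far as these compounds go, it remains open whether an acetyl group or a methyl group in place of the entering group's extra atoms would give a number nearer compound 3 or nearer compound 4.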